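A few compounds are considered here, and "the series" means these few. Any claim that something is new, unique, unknown or untested is made for them only; others in the source may bear on it.

Compound 1 `CC(C)NC(=O)c1ccc(NCc2cncn2Cc2ccc(C#N)cc2)cc1-c1ccccc1` and compound 2 `COC(=O)[C@H](CCSC)NC(=O)c1ccc(NCc2cncn2Cc2ccc(C#N)cc2)cc1-c1ccccc1` share one core and differ only in the group on an amide-type nitrogen. In a functional assay on NIH3T3 cells (Mus musculus) (a lower number here means that less compound is needed, a higher number that more compound is needed for the effect), compound 1 gives > 10 uM, which is a limit of the assay and not a number. In this assay compound 2 gives > 10 uM, again a limit rather than a number. The step that the two limits leave unreadable from compound 1 to compound 2 is therefore unreadable, and the limit of > 10 uM in this assay, at which 2 of the 2 values shown sit, describes where both values sit. Compound 3 `CSCNC(=O)c1ccc(NCc2cncn2Cc2ccc(C#N)cc2)cc1-c1ccccc1` is the next member of the series; its difference from compound 2 is (methylsulfanyl)methyl in place of 1-(methoxycarbonyl)-3-(methylsulfanyl)propyl on an amide-type nitrogen. Among the measured compounds shown here, the only measured step that bears on this position, a step that the two limits leave unreadable from compound 1 to compound 2, gives no direction, since both groups placed on that nitrogen so far leave the value at the limit. The step from compound 2 to compound 3 is expected to be a step that the limit leaves unreadable from compound 2 to compound 3, that is, no change beyond the scatter, with a fair chance that only a limit is reported once more. Compound 3 is estimated at 15 uM, between 5 uM and 50 uM.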

Compound 3, concentration for half-maximal effect: > 10 uM
Compound 3: a limit, no number; the forecaster's own chance of this, stated with the estimate: 70%; the middle value does not contradict the limit.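

No new step can be read among compound 1, compound 2 and compound 3 in this assay, because all three values stand at one limit of the assay and none is a number: the limit of > 10 uM in this assay, at which 3 of the 3 values shown sit.

The compounds shown leave open where the true values lie and whether any of these groups on the amide-type nitrogen changes the value at all.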